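Working notes: 4-fluorobenzyl to 4-chlorobenzyl step

A few compounds are considered here, and "the series" means these few. Any claim that something is new, unique, unknown or untested is made for them only; others in the source may bear on it.

Measured in a functional assay on MGC-803 cells (Homo sapiens) for cytotoxicity, read by MTT assay, with a stated time of 72 h; a lower number here means a stronger inhibitor, a higher number a weaker inhibitor:
compound 1 `CCNC(=O)N1CCN(C(=S)SCc2cn(Cc3ccc(F)cc3)nn2)CC1` — 2170 nM
compound 2 `CC(C)NC(=O)N1CCN(C(=S)SCc2cn(Cc3ccc(F)cc3)nn2)CC1` — 760 nM

Going by the values given here, compound 2 holds the lowest of the two numbers so far; the only other number belongs to compound 1, and the single measured step, a 2.9-fold lower number from compound 1 to compound 2 (0.46 log units; beyond the scatter), separates them. That step changes the urea substituent and says nothing about the benzyl ring.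

Compound 3 `CC(C)NC(=O)N1CCN(C(=S)SCc2cn(Cc3ccc(Cl)cc3)nn2)CC1` differs from compound 2 by chloro in place of fluoro on an aromatic carbon. Among the compounds with values here, no measured step bears on this position; the one step available, a 2.9-fold lower number from compound 1 to compound 2 (0.46 log units; beyond the scatter), lies on the other end of the shared core and gives no guide to a halogen swap on the aromatic ring. With nothing pointing either way, no shift beyond the scatter is expected in this assay from this exchange.

Compound 3 is therefore estimated at 700 nM, with a range of 300 nM to 1600 nM. This corresponds to an expected 1.1-fold lower number from compound 2 to compound 3 (0.04 log units; within the scatter).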

Compound 3, half-maximal inhibitory concentration: 19900 nM
Estimate against measurement, compound 3: 28-fold (1.45 log units) below; the whole stated range lies below it.
By their numbers in this assay, from the lowest: compound 2; then compound 1; then compound 3.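

In this assay, the halogen on the aromatic carbon, para to a large group, proves to be far from a neutral place to make a change. The exchange of 4-fluorobenzyl for 4-chlorobenzyl gives a 26-fold higher number from compound 2 to compound 3 (1.42 log units; beyond the scatter), and this swap of one halogen atom for another outweighs the change on the urea side, a 2.9-fold lower number from compound 1 to compound 2 (0.46 log units; beyond the scatter). Going by these compounds alone, with only this pair, the higher number can be tied to this one exchange in the isopropyl urea and to nothing wider, and no measurement on hand accounts for the size of the step.

The compounds shown leave open whether the higher number is particular to chloro or also comes with bromo, methyl or methoxy at the same place, and where an unsubstituted benzyl group would fall. Also open, as far as these compounds go, is whether the same exchange has a step of similar size with the ethyl urea of compound 1.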